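The source may report more compounds than this note shows. Statements on the series, on what has been measured and on what is new or still open speak of the compounds shown alone.

Compound 1 `CCCCC#Cc1cc([C@@H]2O[C@H](CO)[C@@H](O)[C@H]2O)n2ncnc(N)c12`: 2900 nM
Compound 2 `Nc1ncnn2c([C@@H]3O[C@H](CO)[C@@H](O)[C@H]3O)cc(C#Cc3ccccc3)c12`: 46900 nM

Among these two compounds, compound 2 gives the highest number in a functional assay on HCT-116 cells (Homo sapiens) for antiproliferative activity, with a stated time of 72 h; a lower number here means a stronger inhibitor, a higher number a weaker inhibitor; the only neighbour is compound 1, and the single measured step, a 16-fold higher number from compound 1 to compound 2 (1.21 log units; beyond the scatter), was large. Compound 3 `Cc1ccccc1-c1cc([C@@H]2O[C@H](CO)[C@@H](O)[C@H]2O)n2ncnc(N)c12` differs from compound 2 by 2-methylphenyl in place of 2-phenylethynyl on an aromatic carbon. No measured step removes the triple bond, so the one step shown bears only loosely on this change: it shows that what hangs on that position can move the number strongly. A moderate step toward a lower number is expected, a 3.1-fold lower number from compound 2 to compound 3 (0.50 log units; beyond the scatter), with wide uncertainty. Compound 3 is estimated at 15000 nM, between 3000 nM and 70000 nM.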

Compound 3, half-maximal inhibitory concentration: > 100000 nM
Compound 3: no number, only a limit; the forecaster's own chance of this, stated with the estimate: 10%; middle value at least 6.6-fold (0.82 log units) from the limit.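

For compound 3 in this assay, the reading is a limit of the assay, not a number: the limit of > 100000 nM in this assay, at which 1 of the 3 values shown sits.

Even so, the limit gives an at least 2.1-fold higher number from compound 2 to compound 3 (0.32 log units; beyond the scatter), and an at least 34-fold higher number from compound 1 to compound 3 (1.53 log units; beyond the scatter). Going by these compounds alone, the earlier compounds showed only that the group on the triple bond matters; this change shows that 2-methylphenyl placed directly on the ring, with no triple bond, gives a weaker result than either alkyne.

As far as these compounds go, whether this loss follows from removing the triple bond or from the 2-methylphenyl group itself stays open. So does the effect of a longer chain on the triple bond, or of an amine at this position.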